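A few compounds are considered here, and "the series" means these few. Any claim that something is new, unique, unknown or untested is made for them only; others in the source may bear on it.

Working notes on the series.

Compound 1 `Cc1ccc(NC(=O)c2cccc(/C=C3\CC(=O)N(c4ccccc4)C3=O)c2)cc1C` is assessed in an ADME assay on SW480 cells (Homo sapiens) for cytotoxicity, read by MTT assay, with a stated time of 72 h; a higher number here means a weaker inhibitor, a lower number a stronger inhibitor. In this assay compound 1 gives only a limit of the assay, > 100000 nM, and no number. Compound 2 `Cc1ccc(N2C(=O)C/C(=C\c3cccc(C(=O)Nc4ccc(Cl)cc4)c3)C2=O)cc1` likewise returns only a limit in this assay, > 100000 nM. Among the compounds with values here, both values therefore sit at the limit of > 100000 nM in this assay, at which 2 of the 2 values shown sit, so compound 1 stands exactly where the one other measured compound stands, and no measured step between the two can be drawn; nothing is known about how either compound binds.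

Compound 3 `CSc1cccc(NC(=O)c2cccc(/C=C3\CC(=O)N(c4ccccc4)C3=O)c2)c1` is not yet measured. Its change from compound 1 is 3-(methylsulfanyl)phenyl in place of 3,4-dimethylphenyl on an amide-type nitrogen. Both shown values being limits, no basis exists for expecting a step beyond the usual scatter in either direction; the step from compound 1 to compound 3 is expected to be none beyond the scatter, a number no higher from compound 1 to compound 3 (the limit leaves the size open). Compound 3 is expected to give 100000 nM, most likely again as a limit, within 30000 nM to 300000 nM.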

Compound 3, half-maximal inhibitory concentration: 74300 nM
Compound 3: the middle estimate sits 1.3-fold (0.13 log units) above what was measured; measured number inside the range.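

Within the data shown here, compound 3 gives the first true number in this assay, which shows that a compound with a group at this place on the amide-type nitrogen can read inside the assay's range, where the other values shown are limits: the limit of > 100000 nM in this assay, at which 2 of the 3 values shown sit. Putting 3-(methylsulfanyl)phenyl in place of 3,4-dimethylphenyl gives an at least 1.3-fold lower number from compound 1 to compound 3 (0.12 log units; that floor lies within the scatter). From the compounds shown here alone, the value of compound 1 is a limit, so this step is only a floor, its true size stays open, and the change cannot yet be said to go beyond the scatter.

Going by these compounds, it remains open whether a methoxy group, an amine or a carboxylic acid in place of the methylsulfanyl group would shift the number beyond the scatter. Also open, on these data alone, is whether a change elsewhere on the core of compound 3 would do so.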